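The source may report more compounds than this note shows. Statements on the series, on what has been measured and on what is new or still open speak of the compounds shown alone.

Measured compounds:
- compound 1, `O=S(=O)(Nc1ccc(Oc2ccccc2)cc1)c1ccc(F)cc1`, in a functional assay on Flp-In T-REx293 cells for antagonist activity at Free fatty acid receptor 1 (Homo sapiens), read by calcium flux (a higher number here means a weaker inhibitor, a lower number a stronger inhibitor), compound 1 gives 12900 nM
- compound 2, `Cc1ccccc1Oc1cc(F)cc(N2Cc3ccccc3S2(=O)=O)c1`, in this assay compound 2 gives 44700 nM

Compound 2 holds the highest number of the two, and its nearest neighbour, compound 1, sits beyond the usual scatter below it. Among the measured compounds shown here, the two share no single-point step, so nothing about the effect of one change can be read from them.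

Compound 3, `O=S1(=O)c2ccccc2CN1c1cc(F)cc(Oc2ccncc2)c1`, has not been measured. It differs from compound 2 in one place: pyridin-4-yl in place of 2-methylphenyl on an oxygen on an aromatic ring. For the measured compounds named here, no measured pair shows this change or one like it, so no step size can be taken from the data. The expectation for compound 3 is a number close to that of compound 2, with no clear direction beyond the scatter, and a real chance that only a limit is reported. The estimated step from compound 2 to compound 3 is a 1.3-fold higher number from compound 2 to compound 3 (0.13 log units; within the scatter). Compound 3 is expected to give 60000 nM in this assay, within 15000 nM to 250000 nM.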

Compound 3, half-maximal inhibitory concentration: > 100000 nM
Compound 3 gave a limit, no number; the forecaster's own chance of this, stated with the estimate: 40%; at least 1.6-fold (0.22 log units) between middle value and limit.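

Pyridin-4-yl in place of 2-methylphenyl on an oxygen on an aromatic ring gives the first single-point step in the series, and in this assay it is an at least 2.2-fold higher number from compound 2 to compound 3 (0.34 log units; beyond the scatter). Compound 3 gives > 100000 nM, which is a limit of the assay and not a number. The change at this position therefore moves the read-out beyond the scatter towards weaker inhibition, but the size of the step stays open on the upper side because the reading ends at a limit: the limit of > 100000 nM in this assay, at which 1 of the 3 values shown sits.

On these data alone, what a plain phenyl on the same oxygen would give remains open, so the shares of the lost methyl and the added ring nitrogen in this step cannot be separated. Also open, as far as these compounds go, is how a carboxylic acid or an amine on the ring carried by this oxygen would read in this assay.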